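Methoxy added to a chalcone-pyrazole series: effect on cytotoxicity

The compounds below may be only part of what the source reports. "The series", "measured", "known", "first", "only" and "open" are said of these compounds alone.

Measured compounds:
compound 1 `COc1ccc(-c2cc(/C=C/C(=O)c3ccc(N)cc3)[nH]n2)cc1` with -29%
compound 2 `COc1ccc(C(=O)/C=C/c2cc(-c3cc(OC)c(OC)c(OC)c3)n[nH]2)cc1OC` with -60%
compound 3 `COc1ccc(-c2cc(/C=C/C(=O)c3ccc(N)cc3)[nH]n2)cc1OC` with -49%

Of the compounds shown here, three have been measured in a functional assay on SF-268 cells (Homo sapiens) for cytotoxicity, read by sulforhodamine B assay, with a stated time of 48 h, tested at 10 uM; on this read-out lower numbers stand for a stronger effect and higher numbers for a weaker effect at the one concentration tested. Compound 1 has the structure `COc1ccc(-c2cc(/C=C/C(=O)c3ccc(N)cc3)[nH]n2)cc1` and gives -29% in this assay. Compound 3, `COc1ccc(-c2cc(/C=C/C(=O)c3ccc(N)cc3)[nH]n2)cc1OC`, gives -49%. The two differ in one place, (methoxy in place of hydrogen on an aromatic carbon), and that change gave the step of a number 20 percentage points lower from compound 1 to compound 3 (beyond the scatter). Compound 2, `COc1ccc(C(=O)/C=C/c2cc(-c3cc(OC)c(OC)c(OC)c3)n[nH]2)cc1OC`, gives -60%, the lowest of the three numbers; the difference between its core and that of compound 1 is not broken down here.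

Compound 4, `COc1cc(C(=O)/C=C/c2cc(-c3cc(OC)c(OC)c(OC)c3)n[nH]2)cc(OC)c1OC`, has not yet been measured. It differs from compound 2 by methoxy in place of hydrogen on an aromatic carbon, which is the same kind of change as that from compound 1 to compound 3, though the place is not the same: here the aromatic carbon is also meta to a methoxy group, which is not true of the place in compound 3. The earlier step in this assay was a number 20 percentage points lower from compound 1 to compound 3 (beyond the scatter). On the strength of that single step, the account expects a step of a number 10 percentage points lower from compound 2 to compound 4 (within the scatter) from compound 2 to compound 4, somewhat smaller because compound 2 already stands at -60%. Compound 4 is therefore estimated at -70%, with the expected range from -90% to -50%.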

Compound 4, a percentage reported as activity, at one concentration (the size of the read-out at that concentration, not a potency): -45%
Compound 4: the middle estimate sits 25 percentage points below what was measured; the measured number lies above the stated range.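

In this assay the new step is a number 15 percentage points higher from compound 2 to compound 4 (beyond the scatter), so the same replacement of hydrogen by methoxy on an aromatic carbon that lowered the number on the core of compound 1 raised it on this second core. Set side by side, the two steps run in opposite directions and cannot be treated as one transferable effect: the same change on two cores in this assay, a number 20 percentage points lower (beyond the scatter) from compound 1 to compound 3 and a number 15 percentage points higher (beyond the scatter) from compound 2 to compound 4, 35 percentage points apart, beyond the scatter of two such steps This shows that, for these two pairs, neither the size nor the direction of the step on one core could be relied on for the other, but it does not show whether the core itself is what matters, since the place differs too, the new methoxy in compound 4 being meta to a methoxy group, and each core supplies only one step.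

The compounds shown leave open whether hydroxyl, ethoxy or chlorine in that same place would move the number in the same direction on both cores. They also leave open whether methoxy at a different place on the ring would repeat the step seen on either core, so a single pair per core remains all there is to go on.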